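Aryl change on the sulfonyl sulfur: compound 2 to compound 4

The source may hold more compounds than are shown below. What is called first, only, known or untested is meant among the compounds shown, and "the series" means these compounds.

Three compounds of the shared core have numbers in an assay on isolated protein for displacement of a labelled ligand from metabotropic glutamate receptor 5 (Homo sapiens), with a stated time of 60 min, tested at 1 uM; on this read-out higher numbers stand for more inhibition at the one concentration tested (going by the name of the read-out) and lower numbers for less inhibition. Compound 1 `CC1CCN(c2c(S(=O)(=O)c3ccc(F)cc3)cnc3cc(Cl)ccc23)CC1` gives 91%, compound 2 `Cc1cc(C)cc(S(=O)(=O)c2cnc3cc(F)ccc3c2N2CCC(C)CC2)c1` gives 80%, and compound 3 `CC1CCN(c2c(S(=O)(=O)c3ccc(C#N)cc3)cnc3cc(Cl)ccc23)CC1` gives 70%. Compound 2 lies beyond the scatter below compound 1 and within the scatter of compound 3; compound 1 and compound 2 differ in two places, so only their two values are compared. Within the data shown here, the one single-point step runs on the ring carried by the sulfonyl sulfur: a number 21 percentage points lower from compound 1 to compound 3 (beyond the scatter).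

Compound 4 `CC1CCN(c2c(S(=O)(=O)c3cc(Cl)cc(Cl)c3)cnc3cc(F)ccc23)CC1` differs from compound 2 as follows: 3,5-dichlorophenyl in place of 3,5-dimethylphenyl on a sulfonyl sulfur. The measured step concerns a different pair of groups on that ring, so it gives direction only loosely; compound 1, with a halogen on that ring, holds the highest number, while the cyano step went lower. No step beyond the scatter is expected, so compound 4 is expected at 80%, between 62% and 93%. The estimated step is no change at the digits printed from compound 2 to compound 4 (within the scatter) from compound 2 to compound 4.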

Compound 4, a percentage reported as inhibition, at one concentration (the size of the read-out at that concentration, not a potency): 87%
The estimate for compound 4 lay 7 percentage points below the measured number; the range from low to high includes it.
By their numbers in this assay, from the lowest: compounds 3, 2, 4 and 1 (each within the scatter of the next, the first and the last beyond it).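

In this assay, 3,5-dichlorophenyl in place of 3,5-dimethylphenyl on a sulfonyl sulfur gives a number 7 percentage points higher from compound 2 to compound 4 (within the scatter), the first single-change step read on the core of compound 2. Among these compounds, this ring therefore carries either of these two groups with no step beyond the scatter, whereas the only earlier step on it, a number 21 percentage points lower from compound 1 to compound 3 (beyond the scatter), did go beyond the scatter, on a different pair of groups and a different core. No measurement available here bears on why the two groups give numbers within the scatter of each other.

Open, on these data alone, is how an amine or a carboxylic acid on this ring would read in this assay. Also open, as far as these compounds go, is whether the same exchange of groups gives a step within the scatter on the core of compound 1.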